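Replacing the Dihydroxyphenyl Arm with a Methylphenyl Group

A few compounds are considered here, and "the series" means these few. Any claim that something is new, unique, unknown or untested is made for them only; others in the source may bear on it.

Compound 1 `COc1cc(-c2cc(-c3ccc(N)cc3)nc(-c3ccccc3)n2)cc(OC)c1OC` gives 12300 nM in a functional assay on HCT-116 cells (Homo sapiens) for inhibition, read by MTT assay, with a stated time of 48 h; a lower number here means a stronger inhibitor, a higher number a weaker inhibitor.
Compound 2 `COc1cc(-c2cc(-c3ccc(O)cc3O)nc(-c3ccccc3)n2)cc(OC)c1OC` gives 5890 nM in this assay.

Both compounds share one core and differ only in the aryl group attached to it. Compound 2 stands with the lowest of the two numbers; its nearest neighbour is compound 1, and the step of a 2.1-fold lower number from compound 1 to compound 2 (0.32 log units; beyond the scatter) is modest but beyond the scatter. Compound 3 `COc1cc(-c2cc(-c3ccc(C)cc3)nc(-c3ccccc3)n2)cc(OC)c1OC` has not yet been measured. It differs from compound 2 as follows: 4-methylphenyl in place of 2,4-dihydroxyphenyl on an aromatic carbon. Among the compounds with values here, the only measured step that touches this position is a 2.1-fold lower number from compound 1 to compound 2 (0.32 log units; beyond the scatter), where the 2,4-dihydroxyphenyl group gave the lower number. Removing that group for 4-methylphenyl, which carries no donors or acceptors, is therefore expected to move the number back up, most likely by a modest amount near the size of the earlier step, though a result within the scatter cannot be excluded. Compound 3 is expected to give 15000 nM in this assay, between 6000 nM and 40000 nM. This corresponds to an expected step of a 2.5-fold higher number from compound 2 to compound 3 (0.41 log units; beyond the scatter).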

Compound 3, half-maximal inhibitory concentration: 15700 nM
Compound 3: middle estimate off by 1.0-fold (0.02 log units), on the low side; the measured number falls inside the stated range.
By their numbers in this assay, from the lowest: compound 2; then compounds 1 and 3 (each within the scatter of the next).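

In this assay, the second measured change at this position moves the number the other way: 4-methylphenyl in place of 2,4-dihydroxyphenyl gives a 2.7-fold higher number from compound 2 to compound 3 (0.43 log units; beyond the scatter) and so undoes the gain seen for compound 2. The comparison of the two arms without the dihydroxy pattern gives a 1.3-fold higher number from compound 1 to compound 3 (0.11 log units; within the scatter), so methyl in place of amino makes no readable difference here, and of the three compounds only compound 2 stands apart. Nothing available explains why the 2,4-dihydroxyphenyl arm gives the lower number.

Going by these compounds, it remains open whether the lower number needs the full 2,4-dihydroxyphenyl pattern or whether a phenyl arm carrying a methoxy group or a carboxylic acid would also give it. On these data alone, how far this difference holds on any other core also stays open.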